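Chalcone series: hydrogen in place of nitro on compound 3

The compounds below may be only part of what the source reports. "The series", "measured", "known", "first", "only" and "open" are said of these compounds alone.

The series shares the core seen in compound 1 `CC1(C)Cc2c(OCc3ccccc3)ccc(C(=O)/C=C/c3ccccc3)c2O1`. In a functional assay on B16 cells (Mus musculus) for antiproliferative activity, read by MTT assay, with a stated time of 48 h (a higher number here means a weaker inhibitor, a lower number a stronger inhibitor), compound 1 gives 30300 nM. Compound 2 `CC1(C)Cc2c(OCc3ccccc3)ccc(C(=O)/C=C/c3ccc(F)cc3)c2O1` carries fluoro in place of hydrogen on an aromatic carbon. In this assay compound 2 reaches only a limit of the assay, > 100000 nM. For the measured compounds named here, the step of an at least 3.3-fold higher number from compound 1 to compound 2 (0.51 log units; beyond the scatter) is the only step in the set with a number at both ends. Compound 3 `CC1(C)Cc2c(OCc3ccccc3)ccc(C(=O)/C=C/c3cn(-c4ccccc4)nc3-c3ccc([N+](=O)[O-])cc3)c2O1` carries the 4-nitrophenyl group. In this assay compound 3 also sits at a limit of the assay, > 100000 nM. Where compound 3 stands is thus known only as a limit, and the set as a whole is marked by the limit of > 100000 nM in this assay, at which 2 of the 3 values shown sit.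

Compound 4 `CC1(C)Cc2c(OCc3ccccc3)ccc(C(=O)/C=C/c3cn(-c4ccccc4)nc3-c3ccccc3)c2O1` differs from compound 3 by hydrogen in place of nitro on an aromatic carbon; cut one bond further out, 4-nitrophenyl to phenyl. Going by the values given here, no measured step touches a nitro group; the one measured step, an at least 3.3-fold higher number from compound 1 to compound 2 (0.51 log units; beyond the scatter), sits in another part of the structure and itself ran into a limit, so it gives no direction for the present change. Compound 3 stands at a limit. A value for compound 4 is expected in the weak range near that limit, with a fair chance of another limit. The expected step is an at least 1.2-fold lower number from compound 3 to compound 4 (0.09 log units; that floor lies within the scatter), which is not beyond the scatter. For compound 4 the estimate in this assay is 80000 nM, with a range from 20000 nM to 300000 nM.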

Compound 4, half-maximal inhibitory concentration: > 100000 nM
Compound 4 ended at the assay's limit (the forecaster's own chance of this, stated with the estimate: 65%); at least 1.2-fold (0.09 log units) between middle value and limit.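

Compound 3 and compound 4 both sit at a limit in this assay, so hydrogen in place of nitro yields no readable step between them: the limit of > 100000 nM in this assay, at which 3 of the 4 values shown sit.

The compounds shown leave open whether going from 4-nitrophenyl to phenyl changes activity at all in this assay; neither end of this pair carries a number.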